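The source may hold more compounds than are shown below. What is called first, only, known or untested is meant among the compounds shown, and "the series" means these compounds.

Working notes on the series. For the measured compounds named here, compound 1 `COc1ccc2[nH]c(C(=O)N3CC(=O)N(Cc4ccccc4)[C@@H](COc4ccccc4)C3)cc2c1` gives in an ADME assay on microsomes from liver (Homo sapiens) for metabolic stability, with a stated time of 30 min, tested at 1 uM (on this read-out lower numbers stand for a shorter-lived compound and higher numbers for a longer-lived compound), a value of 0.65 h, the highest of the three numbers measured so far. Compound 3 `COc1ccc2[nH]c(C(=O)N3CC(=O)N(Cc4ccccc4)[C@@H](N4CCC(Cc5ccccc5)CC4)C3)cc2c1` gives in this assay a value of 0.597 h, which lies within the scatter of compound 1. Compound 2 `COc1cccc(CN2C(=O)CN(C(=O)c3cc4cc(OC)ccc4[nH]3)C[C@@H]2CCc2ccccc2)c1` gives in this assay a value of 0.12 h, which lies beyond the scatter from compound 1. Going by the values given here, no pair of measured compounds differs in only one place, so no single step is available as a guide.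

Compound 4 `COc1ccc2[nH]c(C(=O)N3CC(=O)N(Cc4ccccc4)[C@@H](CN4CC5CC5C4)C3)cc2c1` has not yet been measured. It differs from compound 1 in one place: a group of 6 heavy atoms (5 carbon, 1 nitrogen; one three-membered non-aromatic ring of carbon only, one five-membered non-aromatic ring with 1 hetero atom) in place of a group of 7 heavy atoms (6 carbon, 1 oxygen; one six-membered aromatic ring of carbon only), on a saturated chain carbon bound to a saturated ring carbon. The phenoxy group leaves and the new group, with one three-membered non-aromatic ring of carbon only and one five-membered non-aromatic ring with one hetero atom, enters on a saturated chain carbon bound to a saturated ring carbon.

Given that compound 3 gives 0.597 h within the scatter of compound 1, the step from compound 1 to compound 4 is expected to be a 1.2-fold lower number from compound 1 to compound 4 (0.07 log units; within the scatter), not beyond the scatter. Compound 4 is accordingly estimated at 0.55 h, with a range from 0.25 h to 1.2 h.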

Compound 4, half-life: 0.35 h
The estimate for compound 4 lay 1.6-fold (0.20 log units) above the measured number; low and high end bracket the measured number.
By their numbers in this assay, from the lowest: compound 2; then compounds 4, 3 and 1 (each within the scatter of the next).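

In this assay, the series now has its first single-place comparison, a 1.9-fold lower number from compound 1 to compound 4 (0.27 log units; within the scatter), where the phenoxy group is replaced on a saturated chain carbon bound to a saturated ring carbon. At this place, a group with a three-membered non-aromatic ring of carbon only and a five-membered non-aromatic ring with one hetero atom therefore stays within the scatter of phenoxy, so this one change shows no loss of half-life beyond that scatter. Nothing available explains the size or direction of the step.

From the compounds shown here alone, whether a simple pyrrolidine without the three-membered ring would behave in the same way remains open. Also open, going by these compounds, is what a carboxylic acid or a longer chain at this place would do to the half-life.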